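A few compounds are considered here, and "the series" means these few. Any claim that something is new, unique, unknown or untested is made for them only; others in the source may bear on it.

Measured so far:
compound 1 `COc1ccc(/C=C2\N=C3C=CC=CN3C2=O)cc1`: 60 nM
compound 2 `COc1cccc(/C=C2\N=C3C=CC=CN3C2=O)c1`: 80 nM

In a functional assay on HEK-293T cells (Homo sapiens) for inhibition, read by MTT assay, with a stated time of 48 h (a lower number here means a stronger inhibitor, a higher number a weaker inhibitor), compound 1 gives 60 nM and compound 2 gives 80 nM. Within the data shown here, these two values lie within the scatter of each other, so compound 1 stands level with the only other measured compound, and the series offers no order yet.

The next compound is compound 3 `O=C1/C(=C/c2ccc(Cl)cc2)N=C2C=CC=CN12`, which has chloro in place of methoxy on an aromatic carbon, para to a large group: chloro in place of methoxy on an aromatic carbon. Among the measured compounds shown here, no measured step shows what such a replacement does, so the expectation rests on little. No step beyond the scatter is expected, in either direction. The estimated change is a 1.2-fold higher number from compound 1 to compound 3 (0.07 log units; within the scatter). In this assay the estimate for compound 3 is 70 nM, with an expected range of 25 nM to 200 nM.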

Compound 3, half-maximal inhibitory concentration: 30 nM
Compound 3: the middle estimate sits 2.3-fold (0.37 log units) above what was measured; the range from low to high includes it.
By their numbers in this assay, from the lowest: compounds 3, 1 and 2 (each within the scatter of the next, the first and the last beyond it).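

In this assay, chloro in place of methoxy on an aromatic carbon, para to a large group, gives a 2.0-fold lower number from compound 1 to compound 3 (0.30 log units; within the scatter), so this exchange does not move the number beyond the usual scatter. Among these compounds, this is the first step that can be read at this position: the position keeps a number in the same range after methoxy, with its hydrogen-bond acceptor, gives way to chloro, which has none. Nothing at hand explains the size or direction of this step.

The compounds shown leave open how an amine or a carboxylic acid would read at this position. Going by these compounds, whether a longer chain in place of methoxy keeps the number in this range, and whether chloro would behave alike elsewhere on the ring, also remains open.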